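The source may hold more compounds than are shown below. What is called first, only, known or untested is meant among the compounds shown, and "the series" means these compounds.

Working notes on the series.

The shared core of compound 1 `COc1cccc(OC)c1OCCNCCOc1ccccc1OCc1ccccc1` carries a benzyloxy group on the second aromatic ring; in a functional assay on PC-3 cells (Homo sapiens) for cytotoxicity, read by sulforhodamine B assay (a higher number here means a weaker inhibitor of growth, a lower number a stronger inhibitor of growth), compound 1 gives 26900 nM. Compound 2 `COc1cccc(OC)c1OCCNCCOc1ccccc1OCc1ccccc1[N+](=O)[O-]` adds a nitro group to that benzyl ring, and in this assay compound 2 gives 13200 nM. Compound 3 `COc1cccc(OC)c1OCCNCCOc1ccccc1OCc1cccc([N+](=O)[O-])c1` places the nitro at the other ring position and in this assay compound 3 gives 13200 nM. The two nitro additions run alike: a 2.0-fold lower number from compound 1 to compound 2 (0.31 log units; beyond the scatter) and a 2.0-fold lower number from compound 1 to compound 3 (0.31 log units; beyond the scatter). Between the two nitro isomers there is nothing to separate: no change at the digits printed from compound 2 to compound 3 (within the scatter). Compound 3 thus sits level with compound 2 at the digits shown, the two sharing the lowest number of the three, with compound 1 the furthest away.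

Compound 4 `COc1cccc(OC)c1OCCNCCOc1ccccc1OCc1ccc([N+](=O)[O-])cc1` carries the change (4-nitrophenyl in place of 3-nitrophenyl on a saturated chain carbon bound to an oxygen on an aromatic ring). Within the data shown here, the one step that bears directly on it, the move of the nitro from one ring position to another, is the step from compound 2 to compound 3, which stayed within the scatter; the two steps from compound 1 show only that a nitro group on this ring is worth a modest gain, whichever position it occupies. Among the measured compounds shown here, no step in the set points to a further change on moving the nitro again, so for compound 4 in this assay the expected step is a 1.0-fold lower number from compound 3 to compound 4 (0.01 log units; within the scatter), none beyond the scatter. Compound 4 is therefore estimated at 13000 nM, with a range from 6500 nM to 26000 nM.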

Compound 4, concentration for 50% growth inhibition: 12000 nM
The estimate for compound 4 lay 1.1-fold (0.03 log units) above the measured number; low and high end bracket the measured number.
By their numbers in this assay, from the lowest: compounds 4, 2 and 3 (each within the scatter of the next); then compound 1.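

With 4-nitrophenyl on the saturated chain carbon bound to an oxygen on an aromatic ring, the 2-nitrophenyl, 3-nitrophenyl and 4-nitrophenyl isomers can now be read together, and in this assay the placement of the nitro group does not separate them (a 1.1-fold lower number from compound 3 to compound 4 (0.04 log units; within the scatter)) (a 1.1-fold lower number from compound 2 to compound 4 (0.04 log units; within the scatter)). The modest gain from adding a nitro group also recurs with this third isomer (a 2.2-fold lower number from compound 1 to compound 4 (0.35 log units; beyond the scatter)), so all three nitro compounds lie beyond the scatter from compound 1, with none going against the pattern. No measurement available here accounts for this lack of dependence on nitro placement.

Going by these compounds, whether the gain belongs to the nitro group itself or would also appear with an amine, a nitrile or a carboxylic acid on the same ring remains open. Also open, on these data alone, is whether the same indifference to placement would hold with a longer chain in place of the single saturated carbon that carries the nitrophenyl ring, or with two nitro groups on that ring.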